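Working notes on a trifluoromethyl series, compounds 1 to 3

The source may report more compounds than this note shows. Statements on the series, on what has been measured and on what is new or still open speak of the compounds shown alone.

Measured so far:
Compound 1 `O=C(O)CNc1cccc(CNc2cc(C(F)(F)F)cc3[nH]ncc23)c1` — 8%
Compound 2 `FC(F)(F)c1cc(NCc2cccc3sccc23)c2cn[nH]c2c1` — 3%

In an assay for inhibition of Indoleamine 2,3-dioxygenase 1 (Homo sapiens), with stated times of 10 min and 60 min, tested at 100 uM (on this read-out higher numbers stand for a stronger effect at the one concentration tested and lower numbers for a weaker effect), compound 1 gives 8% and compound 2 gives 3%; the two values lie within the usual scatter of each other, so neither stands apart and both read as weak effects at this concentration. Compound 3 `O=C(O)c1cccc(CNc2cc(C(F)(F)F)cc3[nH]ncc23)c1` remains to be measured. It differs from compound 1 by carboxy in place of (carboxymethyl)amino on an aromatic carbon. Going by the values given here, no step between measured compounds covers a change of this kind, so a step of no size beyond the scatter is expected, a number 2 percentage points lower from compound 1 to compound 3 (within the scatter). Compound 3 is accordingly estimated at 6%, with a range from -5% to 18%.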

Compound 3, a percentage reported as inhibition, at one concentration (the size of the read-out at that concentration, not a potency): 17%
Beside the measured number, compound 3's estimate is 11 percentage points below it; low and high end bracket the measured number.
By their numbers in this assay, from the lowest: compounds 2, 1 and 3 (each within the scatter of the next, the first and the last beyond it).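

Carboxy in place of (carboxymethyl)amino on this aromatic carbon gives a number 9 percentage points higher from compound 1 to compound 3 (within the scatter) in this assay. Going by these compounds alone, this position therefore accepts the shorter group without a step beyond the scatter, though this single-concentration read-out gives no potency for either compound. Nothing available bears on the reason for this outcome.

As far as these compounds go, whether a primary amide, a methyl ester or a tetrazole on this aromatic carbon would give a step beyond the scatter remains open. Also open, from the compounds shown here alone, is whether a longer chain ending in a sulfonamide would do so.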